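This account rests on a few compounds, and the source may have more. Where it says the series, first, only, none or still open, it means among the compounds named here.

Measured compounds:
compound 1 `CO[C@@H]1[C@@H](O)[C@@H](O)[C@H]2O[C@]1(C)n1c3ccccc3c3c4c(c5c6ccccc6n2c5c31)C(=O)NC4`, 1010 nM
compound 2 `CO[C@@H]1C(=O)C[C@H]2O[C@]1(C)n1c3ccccc3c3c4c(c5c6ccccc6n2c5c31)C(=O)NC4`, > 2500 nM
compound 3 `C[C@]12O[C@H](C[C@]1(O)C(=O)O)n1c3ccccc3c3c4c(c5c6ccccc6n2c5c31)C(=O)NC4=O`, 1860 nM

In an assay on isolated protein for inhibition of protein kinase C theta type (Homo sapiens), read by HTRF (on this read-out lower numbers stand for stronger inhibition and higher numbers for weaker inhibition), compound 1 gives 1010 nM, the smaller of the two numbers obtained, though the gap to compound 3 at 1860 nM lies within the scatter. For compound 2 this assay reports only a limit, > 2500 nM. The step under consideration leads from compound 1 to compound 4 `CO[C@@H]1[C@@H](O)[C@@H](O)[C@H]2O[C@]1(C)n1c3ccccc3c3c4c(c5c6ccccc6n2c5c31)C(=O)N[C@H]4OC`, and the change is methoxy in place of hydrogen on a saturated ring carbon. Among the compounds with values here, no measured pair shows this change, so the expected step of a 1.5-fold higher number from compound 1 to compound 4 (0.17 log units; within the scatter) is small, with a lean toward a weaker result, and not clearly beyond the scatter. Compound 4 is therefore expected to give about 1500 nM in this assay, between 500 nM and 4500 nM.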

Compound 4, half-maximal inhibitory concentration: > 2500 nM
Compound 4 ended at the assay's limit (the forecaster's own chance of this, stated with the estimate: 20%); middle value at least 1.6-fold (0.22 log units) away from the limit.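

Methoxy in place of hydrogen on this saturated ring carbon, next to the ring nitrogen, is the first change in a single place that can be read here, and in this assay it brings an at least 2.4-fold higher number from compound 1 to compound 4 (0.39 log units; beyond the scatter). On this one pair, the position does not accept methoxy without a loss. The reading for compound 4 is a limit and not a number, so the full size of the loss stays unknown: the limit of > 2500 nM in this assay, at which 2 of the 4 values shown sit.

On these data alone, what a hydroxyl, an amine or a longer chain on this carbon would give remains open.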